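This account rests on a few compounds, and the source may have more. Where it says the series, first, only, none or still open, it means among the compounds named here.

Measured so far in this series:
compound 1, `COc1cccc(C(=O)Nc2cccc(C(=O)O)c2)c1` — 1040 nM
compound 2, `CCCOc1cccc(C(=O)Nc2cccc(C(=O)O)c2)c1` — 2150 nM

Among the measured compounds shown here, in an assay on isolated protein for agonist activity at Bile acid receptor (Homo sapiens), read by TR-FRET, with a stated time of 3 h, in the absence of a further agent (a higher number here means that more compound is needed for the effect, a lower number that less compound is needed), compound 2 gives 2150 nM, the highest of the two numbers so far; its nearest neighbour is compound 1, which gives 1040 nM. For the measured compounds named here, the only step yet measured, a 2.1-fold higher number from compound 1 to compound 2 (0.32 log units; beyond the scatter), runs in the direction of more compound being needed as the chain on the aromatic oxygen grows.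

Compound 3, `CCCCCOc1cccc(C(=O)Nc2cccc(C(=O)O)c2)c1`, is the next extension of the same chain: ethyl in place of hydrogen on a saturated chain carbon, three bonds along the chain from an oxygen on an aromatic ring. Read one bond further out, the change is propyl to pentyl. The step from compound 1 to compound 2 is the only one that bears on it, and it points to a modest rise in the number. Two more chain carbons added in the same place are therefore expected to give a step of about the same size, or somewhat larger, again upward; a step lying within the scatter cannot be excluded on one precedent alone.

For compound 3 in this assay the expected step is a 2.1-fold higher number from compound 2 to compound 3 (0.32 log units; beyond the scatter), giving an estimate of 4500 nM, with a range from 2000 nM to 10000 nM.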

Compound 3, half-maximal effective concentration: 2540 nM
Compound 3: middle estimate off by 1.8-fold (0.25 log units), on the high side; measured number inside the range.
By their numbers in this assay, from the lowest: compound 1; then compounds 2 and 3 (each within the scatter of the next).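

In this assay the change from propyl to pentyl, on a saturated chain carbon three bonds along the chain from an oxygen on an aromatic ring, gives a 1.2-fold higher number from compound 2 to compound 3 (0.07 log units; within the scatter) and so leaves compound 2 and compound 3 unresolved from each other. The upward step seen on the first extension of the chain therefore does not continue measurably at this position, and the added ethyl has no readable effect here. Butyl in place of hydrogen on the saturated chain carbon bound to the oxygen still gives a 2.4-fold higher number from compound 1 to compound 3 (0.39 log units; beyond the scatter) overall, so the methyl ether keeps its separation from the pentyl ether even though the two longer chains cannot be ordered, and no supporting data bear on the reason for this levelling.

Going by these compounds, whether a longer chain such as heptyl stays level with these two or shifts the number again remains open. Also open, on these data alone, is whether a chain ending in an amine, a hydroxyl or a phenyl ring would follow the plain alkyl chains, and whether a free hydroxyl on the aromatic ring would lie on the other side of the methyl ether.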